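Benzofuran for Thiophene on Two Nucleoside Cores

A few compounds are considered here, and "the series" means these few. Any claim that something is new, unique, unknown or untested is made for them only; others in the source may bear on it.

Compound 1 `O=c1[nH]cnc2c1c(-c1cccs1)cn2[C@@H]1O[C@H](CO)[C@@H](O)[C@H]1O` was tested in a functional assay on A549 cells (Homo sapiens), read by MTT assay, with a stated time of 72 h; on this read-out higher numbers stand for weaker inhibition and lower numbers for stronger inhibition. In this assay compound 1 gives only a limit of the assay, > 20000 nM. Compound 2 `O=c1[nH]cnc2c1c(-c1cc3ccccc3o1)cn2[C@@H]1O[C@H](CO)[C@@H](O)[C@H]1O` carries 1-benzofuran-2-yl in place of thiophen-2-yl on an aromatic carbon. In this assay compound 2 likewise gives only a limit, > 20000 nM. The step that the two limits leave unreadable from compound 1 to compound 2 therefore cannot be read. Compound 3 `CN(C)c1ncnc2c1c(-c1cccs1)cn2[C@@H]1O[C@H](CO)[C@@H](O)[C@H]1O` has a different core from compound 1; the difference between the two cores is not broken down here. In this assay compound 3 also gives only a limit, > 20000 nM. Compound 4 `CN(C)c1ncnc2c1c(-c1cc3ccccc3o1)cn2[C@@H]1O[C@H](CO)[C@@H](O)[C@H]1O` is not yet measured; it carries 1-benzofuran-2-yl in place of thiophen-2-yl on an aromatic carbon, the same change as from compound 1 to compound 2, at the same place. That earlier step stayed unreadable and all three values rest on (the limit of > 20000 nM in this assay, at which 3 of the 3 values shown sit), so for compound 4 the step that the limit leaves unreadable from compound 3 to compound 4 is expected to leave it at that limit. Compound 4 is estimated at 30000 nM, within 15000 nM to 100000 nM, most likely reported again only as a limit.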

Compound 4, half-maximal inhibitory concentration: > 20000 nM
Compound 4: only a limit was reported; the forecaster's own chance of this, stated with the estimate: 85%; the middle value lies beyond the limit too.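

The step from compound 3 to compound 4 cannot be read, as with the earlier step from compound 1 to compound 2, because both pairs rest only on limits: the limit of > 20000 nM in this assay, at which 4 of the 4 values shown sit. The compounds shown leave open how thiophen-2-yl and 1-benzofuran-2-yl compare on either core in this assay.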